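Heteroaryl exchange on the ring amine nitrogen: compound 3

The source may hold more compounds than are shown below. What is called first, only, known or untested is meant among the compounds shown, and "the series" means these compounds.

Measured so far:
- Compound 1 `CC1(C)[C@@H]2CC[C@@]1(CS(=O)(=O)N1CCN(c3cc(C(F)(F)F)ccn3)CC1)C(=O)C2`: in a functional assay on CHO-K1 cells for antagonist activity at C-X-C chemokine receptor type 3 (Homo sapiens), read by FLIPR and calcium flux (on this read-out higher numbers stand for weaker inhibition and lower numbers for stronger inhibition), compound 1 gives 25100 nM.
- Compound 2 `CC(=O)c1ccc(N2CCN(S(=O)(=O)C[C@]34CC[C@H](CC3=O)C4(C)C)CC2)nc1`: in this assay compound 2 gives > 31600 nM, which is a limit of the assay and not a number.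

Compound 2 therefore stands at the limit of > 31600 nM in this assay, at which 1 of the 2 values shown sits. For the measured compounds named here, the one measured step, an at least 1.2-fold higher number from compound 1 to compound 2 (0.10 log units; that floor lies within the scatter), has a floor that lies within the scatter, so it gives only a direction at most and no settled size.

The change now followed is 6-(trifluoromethyl)pyridazin-3-yl in place of 5-acetylpyridin-2-yl on an amine nitrogen in a ring, giving compound 3 `CC1(C)[C@@H]2CC[C@@]1(CS(=O)(=O)N1CCN(c3ccc(C(F)(F)F)nn3)CC1)C(=O)C2`. Going by the values given here, no measured step involves a pyridazin-3-yl group, so the only bearing evidence is the step already named and the value of compound 1, which also carries a trifluoromethyl group on its six-membered aromatic ring. Compound 3 is thus expected to sit near compound 1 or at the limit, and the step of an at least 1.0-fold lower number from compound 2 to compound 3 (0.02 log units; that floor lies within the scatter) is expected to be none beyond the scatter. Compound 3 is estimated at 30000 nM, with a range from 12000 nM to 90000 nM, and a substantial chance that only a limit is reported.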

Compound 3, half-maximal inhibitory concentration: 5010 nM
Compound 3: middle estimate off by 6.0-fold (0.78 log units), on the high side; measured number outside the range, below it.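

In this assay, the exchange on the amine nitrogen in a ring now gives a step of settled size beyond the scatter, between two groups that both carry trifluoromethyl: a 5.0-fold lower number from compound 1 to compound 3 (0.70 log units; beyond the scatter), with 6-(trifluoromethyl)pyridazin-3-yl in place of 4-(trifluoromethyl)pyridin-2-yl. The presence of trifluoromethyl alone therefore does not set the number at this position, and the same entering group also gives an at least 6.3-fold lower number from compound 2 to compound 3 (0.79 log units; beyond the scatter) in place of 5-acetylpyridin-2-yl. That second step is only a floor, since compound 2 is held at a limit of the assay and not at a number: the limit of > 31600 nM in this assay, at which 1 of the 3 values shown sits.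

Between compound 1 and compound 3, the hetero atoms of the aromatic ring and the place of trifluoromethyl change together, and the compounds shown do not separate the two. Also open, on these data alone, is whether a nitrile or a carboxylic acid in place of trifluoromethyl on the pyridazin-3-yl group would keep, lower or raise the number in this assay.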